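This account rests on a few compounds, and the source may have more. Where it says the series, first, only, none or still open, it means among the compounds named here.

Compound 1 `CC(C)[C@H](NC(=S)NCc1ccccc1)c1nc2ccccc2[nH]1` gives 48500 nM in a functional assay on DU-145 cells (Homo sapiens) for cytotoxicity, read by MTT assay; a higher number here means a weaker inhibitor, a lower number a stronger inhibitor. Compound 2 `CC(C)[C@@H](NC(=S)NCc1ccccc1)c1nc2ccccc2[nH]1` gives 17300 nM in this assay.

In this assay compound 2 gives the lower of the two numbers; the step from compound 1 to compound 2 was a 2.8-fold lower number from compound 1 to compound 2 (0.45 log units; beyond the scatter), a change that rests only on (the fact that compounds 1 and 2 differ only in the configuration as drawn). Compound 3 `C[C@@H](NC(=S)NCc1ccccc1)c1nc2ccccc2[nH]1` differs from compound 2 by methyl in place of isopropyl on a saturated chain carbon bound to an amide-type nitrogen and an aromatic carbon. Within the data shown here, no measured step alters this group, so nothing measured points to a direction. The step from compound 2 to compound 3 is therefore expected to be a 1.4-fold higher number from compound 2 to compound 3 (0.16 log units; within the scatter), none beyond the scatter. Compound 3 is estimated at 25000 nM, with a range from 8000 nM to 80000 nM.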

Compound 3, half-maximal inhibitory concentration: 28700 nM
Beside the measured number, compound 3's estimate is 1.1-fold (0.06 log units) below it; low and high end bracket the measured number.
By their numbers in this assay, from the lowest: compounds 2, 3 and 1 (each within the scatter of the next, the first and the last beyond it).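

Methyl in place of isopropyl on this saturated chain carbon gives a 1.7-fold higher number from compound 2 to compound 3 (0.22 log units; within the scatter) in this assay, the first measured change to this group rather than to its configuration as drawn. At this position, then, the two groups cannot be told apart in this measurement, so the full size of isopropyl is not needed to keep the number where it stands. Nothing measured here explains this step. Still open, as far as these compounds go, is whether a longer chain, a phenyl ring or an amine on this carbon would move the number beyond the scatter. Also open, from the compounds shown here alone, is whether the methyl compound responds to its configuration as drawn, as the isopropyl pair does.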